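This account rests on a few compounds, and the source may have more. Where it says the series, first, only, none or still open, it means among the compounds named here.

Measured compounds in a functional assay on OVCAR-3 cells (Homo sapiens) for cytotoxicity, read by sulforhodamine B assay; on this read-out higher numbers stand for weaker inhibition of growth and lower numbers for stronger inhibition of growth:
compound 1 `CC1=CC[C@@H]([C@@](C)(O)CCCC(C)(C)NC=S)CC1` gives 12100 nM
compound 2 `CC1=CC[C@@H]([C@@](C)(O)CCCC(C)(C)NC(=S)NN)CC1` gives 17200 nM

Compound 2 stands at the higher of these two numbers, but its distance from compound 1 is within the scatter: a 1.4-fold higher number from compound 1 to compound 2 (0.15 log units; within the scatter). Compound 3 `CC1=CC[C@@H]([C@@](C)(O)CCCC(C)(C)NC(=S)N/N=C\c2ccccc2)CC1` has not yet been measured. It differs from compound 2 by a group of 8 heavy atoms (7 carbon, 1 nitrogen; one six-membered aromatic ring of carbon only) in place of one nitrogen atom, on an amide-type nitrogen. The only measured step, a 1.4-fold higher number from compound 1 to compound 2 (0.15 log units; within the scatter), concerns the group on the thiocarbonyl carbon and stays within the scatter; no measured step concerns a change on the amide-type nitrogen, and none introduces an aromatic ring, so the present change has no direct precedent among these compounds. A step that is small and of uncertain direction is therefore expected in this assay: a 1.9-fold lower number from compound 2 to compound 3 (0.28 log units; within the scatter). Compound 3 is estimated to give 9000 nM in this assay, within a range from 2500 nM to 35000 nM.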

Compound 3, concentration for 50% growth inhibition: 6970 nM
Beside the measured number, compound 3's estimate is 1.3-fold (0.11 log units) above it, and the stated range covers the measured number.
By their numbers in this assay, from the lowest: compounds 3, 1 and 2 (each within the scatter of the next, the first and the last beyond it).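

In this assay, for the compounds shown here, the change on the amide-type nitrogen gives the first step in this set that lies beyond the scatter (a 2.5-fold lower number from compound 2 to compound 3 (0.39 log units; beyond the scatter)), though only a modest one. The position therefore takes a group of 8 heavy atoms with a six-membered aromatic ring in place of the amino group, and growth inhibition is not lost. Compared with the thiocarbonyl carbon's hydrogen in compound 1, however, the full group leaves the number within the scatter (a 1.7-fold lower number from compound 1 to compound 3 (0.24 log units; within the scatter)), so the step counts only against compound 2.

No measurement on hand accounts for this step. As far as these compounds go, whether a pyridine ring, a chlorophenyl group or a cyclohexyl group in place of the carbon-only aromatic ring would move the number further remains open.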